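The compounds below may be only part of what the source reports. "The series", "measured", "known", "first", "only" and "open" are said of these compounds alone.

In a functional assay on NALM-6 cells (Homo sapiens) for cytotoxicity, with a stated time of 72 h (a higher number here means that more compound is needed for the effect, a lower number that less compound is needed), compound 1 (`C=C[C@@](C)(/C=C/c1ccc(OCc2ccccc2)cc1)CCC=C(C)C`) gives > 43400 nM as a limit, not a number. Compound 2 (`C=C[C@@](C)(/C=C/c1ccc(O)cc1)CC/C=C/C(=O)c1ccccc1`) gives > 43400 nM as a limit too. For the measured compounds named here, compound 1 therefore has no numerical value, and no step between measured compounds is available. Compound 3 (`C=C[C@@](C)(/C=C/c1ccc(Nc2ccc(Cl)c(F)c2)cc1)CCC=C(C)C`) has (4-chloro-3-fluorophenyl)amino in place of benzyloxy on an aromatic carbon. A modest move toward less compound needed in this assay is expected, though a reading at the limit remains quite possible. The estimated step is an at least 1.9-fold lower number from compound 1 to compound 3 (0.29 log units; that floor lies within the scatter) on this tentative basis. Compound 3 is expected at 22000 nM within an estimated range of 7000 nM to 60000 nM for now.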

Compound 3, half-maximal effective concentration: > 43400 nM
Compound 3 gave a limit, no number (the forecaster's own chance of this, stated with the estimate: 50%); middle value at least 1.9-fold (0.29 log units) from the limit.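

No step from compound 1 to compound 3 can be read, because both results are limits and not numbers: the limit of > 43400 nM in this assay, at which 3 of the 3 values shown sit.

The compounds shown leave open which structural change, if any, would give a numerical reading in this assay.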